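This account rests on a few compounds, and the source may have more. Where it says the series, first, only, none or still open, it means among the compounds named here.

Measured so far:
Compound 1, `Cc1n[nH]c(C(=O)O)c1Cc1ccc(C#N)cc1`: 6%
Compound 2, `Cc1n[nH]c(C(=O)O)c1Cc1ccc(C(=O)O)cc1`: 22%
Compound 3, `Cc1n[nH]c(C(=O)O)c1Cc1cccc(C(=O)O)c1`: 0%

All three were tested in an assay on isolated protein for inhibition of 2-Hydroxyacid oxidase 2 (Homo sapiens), tested at 10 uM; on this read-out higher numbers stand for a stronger effect at the one concentration tested and lower numbers for a weaker effect. Compound 2 gives 22%, and going to compound 1 the read-out moves by a number 16 percentage points lower from compound 2 to compound 1 (beyond the scatter); the change behind that step is cyano in place of carboxy on an aromatic carbon. Compound 3 gives 0%; how its core differs from that of compound 2 is not broken down here, the two having the same atoms joined differently.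

Compound 4, `Cc1n[nH]c(C(=O)O)c1Cc1cccc(C#N)c1`, has not yet been measured. It arises from compound 3 by cyano in place of carboxy on an aromatic carbon. This is the same kind of change as that from compound 2 to compound 1, but not the same: there the group sat para to a large group, here it sits meta to a large group. The step from compound 3 to compound 4 in this assay is expected to be about a number 1 percentage points higher from compound 3 to compound 4 (within the scatter), resting on the step of a number 16 percentage points lower from compound 2 to compound 1 (beyond the scatter) and on the low starting value of compound 3, 0%. Compound 4 is therefore estimated at 1%, expected between -6% and 10%.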

Compound 4, a percentage reported as inhibition, at one concentration (the size of the read-out at that concentration, not a potency): 19%
Beside the measured number, compound 4's estimate is 18 percentage points below it; the measured number lies above the stated range.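

In this assay, replacing carboxy with cyano on the aromatic carbon meta to a large group moves the read-out by a number 19 percentage points higher from compound 3 to compound 4 (beyond the scatter). For the compounds shown here, the same replacement therefore cannot be carried from one core to the other with its size and direction assumed to hold, as the two steps go opposite ways: the same change on two cores in this assay, a number 16 percentage points lower (beyond the scatter) from compound 2 to compound 1 and a number 19 percentage points higher (beyond the scatter) from compound 3 to compound 4, 35 percentage points apart, beyond the scatter of two such steps What this does not show is why the direction reverses, and with only one pair on each core it gives no rule for any further core.

The compounds shown leave open whether another group in the same place, such as a primary amide or a tetrazole, would read like carboxy or like cyano on each of the two cores. Also open, going by these compounds, is how these compounds would behave across a range of concentrations: each number here is the size of the effect at a single concentration, and a higher number stands only for a stronger effect at that concentration.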